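Swapping 4-fluorophenyl for 3,4-dimethoxyphenyl: a cytotoxicity estimate

The source may report more compounds than this note shows. Statements on the series, on what has been measured and on what is new or still open speak of the compounds shown alone.

Of the compounds shown here, three that share one core have been measured in an ADME assay on L6 cells (Rattus norvegicus) for cytotoxicity, read by resazurin assay; a lower number here means a stronger inhibitor, a higher number a weaker inhibitor. Compound 1 `N=C(N)c1ccc2[nH]c(-c3ccc4nc(-c5ccc(F)cc5)[nH]c4c3)nc2c1` gives 2.48 ug/mL, the lowest of the three numbers, and its gaps to the other two lie beyond the scatter. Compound 2 `N=C(N)c1ccc2[nH]c(-c3ccc4nc(-c5cc(C(F)(F)F)ccc5Cl)[nH]c4c3)nc2c1` gives 31.8 ug/mL, and compound 3 `N=C(N)c1ccc2[nH]c(-c3ccc4nc(-c5cc(C(F)(F)F)cc(C(F)(F)F)c5)[nH]c4c3)nc2c1` gives 76.8 ug/mL.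

Compound 4 `COc1ccc(-c2nc3ccc(-c4nc5cc(C(=N)N)ccc5[nH]4)cc3[nH]2)cc1OC` has not yet been measured. It differs from compound 1 at one place: 3,4-dimethoxyphenyl in place of 4-fluorophenyl on an aromatic carbon, (3,4-dimethoxyphenyl in place of 4-fluorophenyl on an aromatic carbon). Among the compounds with values here, no measured pair shows this swap directly. Within the data shown here, the only guide is that compound 2 at 31.8 ug/mL and compound 3 at 76.8 ug/mL, which carry other groups at that place, both read higher than compound 1. A moderate rise, probably beyond the scatter, is therefore expected, with an estimated step of a 4.0-fold higher number from compound 1 to compound 4 (0.61 log units; beyond the scatter). The uncertainty is wide. For compound 4 the expected value in this assay is 10 ug/mL, within an estimated range of 2.5 ug/mL to 40 ug/mL.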

Compound 4, half-maximal inhibitory concentration: > 90 ug/mL
Compound 4: only a limit was reported; the forecaster's own chance of this, stated with the estimate: 3%; at least 9.0-fold (0.95 log units) between middle value and limit.
By their numbers in this assay, from the lowest: compound 1; then compound 2; then compound 3. At a limit, above all of these: compound 4.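

In this assay, within the data shown here, replacing 4-fluorophenyl with 3,4-dimethoxyphenyl gives an at least 36-fold higher number from compound 1 to compound 4 (1.55 log units; beyond the scatter), a large step and the first direct reading of a single change at this aromatic carbon between two ring nitrogen atoms. It shows that the group at this place can by itself shift cytotoxicity strongly, with the higher number meaning weaker inhibition of the cells. The reading for compound 4 is a limit and not a number, so the true size of the step stays unknown: the limit of > 90 ug/mL in this assay, at which 1 of the 4 values shown sits.

With only this one direct swap, the compounds shown cannot separate the effect of the two methoxy groups from that of removing the fluorine. As far as these compounds go, it remains open whether a phenyl ring with a single methoxy group, or one carrying an amine or a carboxylic acid, would give a similar rise.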